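A few compounds are considered here, and "the series" means these few. Any claim that something is new, unique, unknown or untested is made for them only; others in the source may bear on it.

Measured compounds:
- compound 1, `N=C(N)NS(=O)(=O)c1ccc(/N=C/c2c(Cl)c3ccccc3oc2=O)cc1`: 58 nM in a functional assay on MCF7 cells (Homo sapiens) for cytotoxicity, read by CCK-8 assay, with a stated time of 48 h; a higher number here means a weaker inhibitor, a lower number a stronger inhibitor
- compound 2, `Cc1cc(NS(=O)(=O)c2ccc(/N=C/c3c(Cl)c4ccccc4oc3=O)cc2)no1`: 12 nM
- compound 3, `CC(C)(C)c1cc(C(C)(C)C)c2oc(=O)c(/C=N/c3ccc(S(=O)(=O)Nc4nccs4)cc3)c(Cl)c2c1`: 12 nM

Compound 3 stands level with compound 2 at the digits printed; together they hold the lowest numbers of the three, and compound 1 sits higher than both, beyond the scatter.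

Compound 4 is `Cc1cc(NS(=O)(=O)c2ccc(/N=C/c3c(Cl)c4cc(C(C)(C)C)cc(C(C)(C)C)c4oc3=O)cc2)no1`. It differs from compound 3 in one place: 5-methyl-1,2-oxazol-3-yl in place of 1,3-thiazol-2-yl on a sulfonamide nitrogen.

Within the data shown here, one measured step touches the same position. The step of a 4.8-fold lower number from compound 1 to compound 2 (0.68 log units; beyond the scatter) shows that putting the 5-methyl-1,2-oxazol-3-yl group on the sulfonamide nitrogen in place of a group of 3 heavy atoms gave a modest drop. The 1,3-thiazol-2-yl to 5-methyl-1,2-oxazol-3-yl exchange itself is not measured directly; compound 2 and compound 3 differ in two places, and their values show no change at the digits printed. Both five-membered rings carry the same count of acceptors and no donor, so no step beyond the scatter is expected in this assay, in either direction.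

For compound 4 the estimate is therefore 12 nM, range 5 nM to 30 nM, which means an expected step of no change at the digits printed from compound 3 to compound 4 (within the scatter).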

Compound 4, half-maximal inhibitory concentration: 64 nM
Compound 4: the middle estimate sits 5.3-fold (0.73 log units) below what was measured, outside the stated range (above it).
By their numbers in this assay, from the lowest: compounds 2 and 3 (each within the scatter of the next); then compounds 1 and 4 (each within the scatter of the next).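

With the core of compound 3 held fixed, the two five-membered aromatic rings on the sulfonamide nitrogen are not interchangeable in this assay: the exchange gives a 5.3-fold higher number from compound 3 to compound 4 (0.73 log units; beyond the scatter), even though both rings have the same hydrogen-bond donor and acceptor counts and no net charge. The 5-methyl-1,2-oxazol-3-yl group therefore has no single reading across the series: a 4.8-fold lower number from compound 1 to compound 2 (0.68 log units; beyond the scatter) records its entry in place of a different group on a different core, with a lower number, whereas here it enters with a higher number. No measurement among these data accounts for the step.

As far as these compounds go, it remains open whether the same exchange gives a step of similar size on the core of compound 2. Also open, from the compounds shown here alone, is how a pyridin-2-yl ring or a simple amine on the sulfonamide nitrogen would read in this assay on either core.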